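The compounds below may be only part of what the source reports. "The series", "measured", "known", "first", "only" and "open" are said of these compounds alone.

In an ADME assay on NHDF cells (Homo sapiens) for cytotoxicity, read by MTT assay, with a stated time of 72 h (a lower number here means a stronger inhibitor, a higher number a weaker inhibitor), compound 1 (`COc1cccc(/C=C2\CCC/C(=C\c3ccc(OC)c(OC)c3)C2=O)c1`) gives 11600 nM and compound 2 (`COc1ccc(/C=C2\CCC/C(=C\c3cccc(Cl)c3Cl)C2=O)cc1OC`) gives 18500 nM while compound 3 (`COc1ccc(/C=C2\CCC/C(=C\c3ccc(O)c(Cl)c3)C2=O)cc1OC`) gives 21900 nM in the same assay. Compound 3 therefore stands within the scatter of the other two. Compound 4 (`COc1ccc(/C=C2\CCC/C(=C\c3ccc(O)c(O)c3)C2=O)cc1OC`) departs from compound 3 in one place, hydroxy in place of chloro on an aromatic carbon, which turns 3-chloro-4-hydroxyphenyl into 3,4-dihydroxyphenyl. Among the compounds with values here, no measured step makes this exchange itself, but three steps alter the same aryl group. These steps, a 1.6-fold higher number from compound 1 to compound 2 (0.20 log units; within the scatter) and a 1.9-fold higher number from compound 1 to compound 3 (0.28 log units; within the scatter) and a 1.2-fold higher number from compound 2 to compound 3 (0.07 log units; within the scatter), all stay within the scatter in this assay despite replacing the whole aryl group. A smaller exchange of one group on that aryl is thus expected to produce no step beyond the scatter, in either direction. The estimated change, a 1.3-fold lower number from compound 3 to compound 4 (0.11 log units; within the scatter), is expected to stay within that scatter. The expected value for compound 4 is 17000 nM with an estimated range from 7000 nM to 40000 nM in this measurement.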

Compound 4, half-maximal inhibitory concentration: 25200 nM
Compound 4: middle estimate off by 1.5-fold (0.17 log units), on the low side, and the stated range covers the measured number.
By their numbers in this assay, from the lowest: compounds 1, 2, 3 and 4 (each within the scatter of the next, the first and the last beyond it).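

In this assay, hydroxy in place of chloro on an aromatic carbon, ortho to a hydroxy group, can now be read directly at this position, and it gives a 1.2-fold higher number from compound 3 to compound 4 (0.06 log units; within the scatter). The larger exchange of the whole aryl group gives a 1.4-fold higher number from compound 2 to compound 4 (0.13 log units; within the scatter), whereas a 2.2-fold higher number from compound 1 to compound 4 (0.34 log units; beyond the scatter) is the only step among these compounds to pass the scatter, and it remains modest. Nothing measured here accounts for any of these steps.

As far as these compounds go, whether an amine or a carboxylic acid in place of this hydroxy group would also stay within the scatter remains open. So does whether a longer chain on this aryl group, or a change to the shared core, would produce a larger step than any seen so far.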